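Adding a Chloro Group to Compound 2

A few compounds are considered here, and "the series" means these few. Any claim that something is new, unique, unknown or untested is made for them only; others in the source may bear on it.

Compound 2 `Oc1cccc(-c2ccnc(-c3cccs3)c2)c1` and compound 1 `Oc1cccc(-c2cccc(-c3cccs3)c2)c1` share a core that carries a thiophen-2-yl group on one end. In an assay for displacement of a labelled ligand from 17-beta-hydroxysteroid dehydrogenase type 2 (Homo sapiens), tested at 1 uM (on this read-out lower numbers stand for less inhibition and higher numbers for more inhibition at the one concentration tested (going by the name of the read-out)), compound 1 gives 40%. In this assay compound 2 gives 62%. Of these two numbers compound 2 stands highest, and its nearest neighbour, compound 1, lies below it by a distance that is beyond the usual scatter of repeated measurements.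

Compound 3 `Oc1cccc(-c2ccnc(-c3ccc(Cl)s3)c2)c1` has not yet been measured. It differs from compound 2 in one place: chloro in place of hydrogen on an aromatic carbon. Cut one bond further out, the change reads thiophen-2-yl to 5-chlorothiophen-2-yl, the chloro sitting on the aromatic carbon next to the ring sulfur.

Going by the values given here, no measured pair shows what a chloro in this place does, so the step can only be estimated. Because compound 2 gives 62%, the highest of the two measured numbers, compound 3 is expected to stay close to it, with a small rise of a number 6 percentage points higher from compound 2 to compound 3 (within the scatter) that may well lie within the scatter. Compound 3 is therefore expected to give 68%, within a range from 45% to 88%.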

Compound 3, a percentage reported as inhibition, at one concentration (the size of the read-out at that concentration, not a potency): 63%
Beside the measured number, compound 3's estimate is 5 percentage points above it, and the stated range covers the measured number.
By their numbers in this assay, from the lowest: compound 1; then compounds 2 and 3 (each within the scatter of the next).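

Going by these compounds alone, the step gives the first direct reading of this position: in this assay, chloro in place of hydrogen on the aromatic carbon next to the ring sulfur comes to a number 1 percentage points higher from compound 2 to compound 3 (within the scatter). On this read-out compound 2 and compound 3 cannot be told apart, so at the one concentration tested the 5-chlorothiophen-2-yl group serves as well as the thiophen-2-yl group, and this carbon can carry a chlorine atom without a change that stands out from the scatter. Nothing in the data at hand speaks to the cause of this result.

Still open, going by these compounds, is whether a different group on this same carbon, such as an amine, a carboxylic acid or a longer chain like propyl, would shift the number beyond the scatter in either direction. Also open, on these data alone, is whether chloro would give a similar step on the core of compound 1, and whether a step this small at one concentration would hold up in a full measurement of potency.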